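The source may hold more compounds than are shown below. What is called first, only, known or untested is meant among the compounds shown, and "the series" means these compounds.

Compound 1 `CCOC(=O)c1c(-c2ccccc2C)[nH]c2cccc(OC)c2c1=O` and compound 2 `CCOC(=O)c1c(-c2cccc(OC)c2)[nH]c2cccc(OC)c2c1=O` share a core and differ in one aromatic group, with 3-methoxyphenyl in compound 2 in place of 2-methylphenyl in compound 1. In a physicochemical assay for solubility, in phosphate buffer, at pH 7.4 (on this read-out higher numbers stand for higher solubility and lower numbers for lower solubility), compound 1 gives > 100000 nM as a limit of the assay, not a number. In this assay compound 2 gives > 100000 nM as a limit too, so it has no exact value here.

Compound 3 `CCOC(=O)c1c(-c2cccc([N+](=O)[O-])c2)[nH]c2cccc(OC)c2c1=O` is still unmeasured. It carries nitro in place of the methoxy of compound 2, on an aromatic carbon of a six-membered aromatic ring of carbon only, meta to a large group (nitro in place of methoxy on an aromatic carbon).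

For the measured compounds named here, the only measured step (a step that the two limits leave unreadable from compound 1 to compound 2) touches this same aromatic group, yet it offers no size to carry over. No step beyond the scatter, in either direction, is therefore expected in this assay for this change.

The expected step is a number no higher from compound 2 to compound 3 (the limit leaves the size open) at this estimate. For compound 3 the estimated value is 100000 nM with an expected range from 30000 nM to 130000 nM in this assay.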

Compound 3, solubility: 49000 nM
Estimate against measurement, compound 3: 2.0-fold (0.31 log units) above; low and high end bracket the measured number.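

In this assay compound 3 gives the first exact number among the compounds shown, so a change at this place on the aromatic group can bring the read-out inside the measurable range. Nitro in place of methoxy gives an at least 2.0-fold lower number from compound 2 to compound 3 (0.30 log units; that floor lies within the scatter), and 3-nitrophenyl in place of 2-methylphenyl gives an at least 2.0-fold lower number from compound 1 to compound 3 (0.30 log units; that floor lies within the scatter). Both steps are floors that do not go beyond the scatter, and their true size stays unknown because each starts from a compound held at a limit: the limit of > 100000 nM in this assay, at which 2 of the 3 values shown sit.

Going by these compounds, whether an amine or a carboxylic acid in place of the nitro would give an exact number in this assay, and how large that number would be, stays open. So does whether nitro in place of methoxy would give a similar step on a different core.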